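The compounds below may be only part of what the source reports. "The series", "measured", "known", "first", "only" and "open" are said of these compounds alone.

In a functional assay on UACC-62 cells (Homo sapiens) for inhibition, read by sulforhodamine B assay, with a stated time of 48 h, tested at 10 uM (on this read-out higher numbers stand for more inhibition at the one concentration tested (going by the name of the read-out) and lower numbers for less inhibition), compound 2 `O=Cc1ccc(-c2cn3ccnc3c(-c3ccc4ncn(C5CCCCC5)c4c3)n2)cc1` gives 37.1%, the lower of the two numbers recorded so far. Within the data shown here, compound 1 `COc1ccc(-c2cn3ccnc3c(-c3ccc4ncn(C5CCCCC5)c4c3)n2)cc1` gives 65.2% in this assay, and the only step in the set, a number 28.1 percentage points lower from compound 1 to compound 2 (beyond the scatter), separates the two.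

Compound 3 `c1cn2cc(-c3ccsc3)nc(-c3ccc4ncn(C5CCCCC5)c4c3)c2n1` has not been measured. It differs from compound 2 by thiophen-3-yl in place of 4-formylphenyl on an aromatic carbon. Among the measured compounds shown here, the one step that touches the same part of the molecule is the change from compound 1 to compound 2, in which a formyl replacing a methoxy on the aromatic ring cost a number 28.1 percentage points lower from compound 1 to compound 2 (beyond the scatter). For the measured compounds named here, that step suggests the formyl-bearing ring sits at the weaker end of what has been seen, so discarding it and putting a thiophen-3-yl in its place is more likely to move the number upward than further down; but no measured step tells how a five-membered ring with one sulfur compares to a phenyl here, so the expectation stays loose. Compound 3 is therefore expected to show a rise of about a number 12.9 percentage points higher from compound 2 to compound 3 (beyond the scatter) in this assay, landing near 50%, with a range from 25% to 75%.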

Compound 3, a percentage reported as inhibition, at one concentration (the size of the read-out at that concentration, not a potency): 18.4%
Compound 3: the middle estimate sits 31.6 percentage points above what was measured; the whole stated range lies above it.
By their numbers in this assay, from the lowest: compound 3; then compound 2; then compound 1.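

In this assay, thiophen-3-yl in place of 4-formylphenyl gives a number 18.7 percentage points lower from compound 2 to compound 3 (beyond the scatter) and so takes the number below both earlier compounds, which shows that the formyl-bearing ring did not mark the low end at this position. Thiophen-3-yl in place of 4-methoxyphenyl gives a number 46.8 percentage points lower from compound 1 to compound 3 (beyond the scatter) as the only step in the set printed as large, so the choice of ring on this aromatic carbon can matter more than the change from methoxy to formyl on the phenyl ring. No supporting evidence accounts for the fall at this position.

The three compounds cannot separate the effects of the smaller ring, the sulfur and the loss of the substituent, as compound 3 differs from compound 1 and compound 2 in all three at once. Also open, from the compounds shown here alone, is how an unsubstituted phenyl, a furan-3-yl, a thiophen-2-yl or a phenyl carrying an amine or a carboxylic acid would compare on this aromatic carbon.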